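Second chloro on the phenyl ring: notes toward compound 4

The compounds below may be only part of what the source reports. "The series", "measured", "known", "first", "only" and "open" are said of these compounds alone.

Measured so far, in a functional assay on A549 cells (Homo sapiens) for inhibition, read by MTT assay, with a stated time of 72 h; a higher number here means a weaker inhibitor, a lower number a stronger inhibitor:
compound 1, `COc1cc2c(Oc3ccc(NC(=O)c4nn(-c5ccccc5)c(=O)cc4C)cc3F)ccnc2cc1OCCCN1CCN(C)CC1`, gives 350 nM
compound 2, `COc1cc2c(Oc3ccc(NC(=O)c4nn(-c5ccc(Cl)cc5)c(=O)cc4C)cc3F)ccnc2cc1OCCCN1CCCCC1`, gives 320 nM
compound 3, `COc1cc2c(Oc3ccc(NC(=O)c4nn(-c5ccc(Cl)cc5)c(=O)cc4C)cc3F)ccnc2cc1OCCCN1CCN(C)CC1`, gives 270 nM

The three numbers in this assay sit close together. The step of a 1.3-fold lower number from compound 1 to compound 3 (0.11 log units; within the scatter) comes from the change (chloro in place of hydrogen on an aromatic carbon), and the step of a 1.2-fold lower number from compound 2 to compound 3 (0.07 log units; within the scatter) comes from a swap at the far end of the chain; neither leaves the scatter. The difference between the cores of compound 1 and compound 2 is not broken down here.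

Compound 4, `COc1cc2c(Oc3ccc(NC(=O)c4nn(-c5ccc(Cl)cc5Cl)c(=O)cc4C)cc3F)ccnc2cc1OCCCN1CCCCC1`, is not yet measured. It differs from compound 2 by chloro in place of hydrogen on an aromatic carbon. This is the same kind of change as that from compound 1 to compound 3, and it occurs twice among the compounds shown, but the place is not identical: in compound 3 the chloro enters para to a large group, whereas in compound 4 it enters ortho to a large group and meta to a chloro group.

Going by the values given here, the only guide to the size of the step still to be measured is a 1.3-fold lower number from compound 1 to compound 3 (0.11 log units; within the scatter), which stayed within the scatter. A step of similar size, a 1.1-fold lower number from compound 2 to compound 4 (0.06 log units; within the scatter), is expected in this assay. Compound 4 is therefore estimated at 280 nM, with a plausible range from 140 nM to 600 nM, because compound 2 gives 320 nM and the earlier chloro step was small.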

Compound 4, half-maximal inhibitory concentration: 220 nM
Beside the measured number, compound 4's estimate is 1.3-fold (0.10 log units) above it; measured number inside the range.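

In this assay, chloro in place of hydrogen on an aromatic carbon gives a 1.5-fold lower number from compound 2 to compound 4 (0.16 log units; within the scatter), and this step sits beside the earlier one as follows: the same change on two cores in this assay, a 1.3-fold lower number (0.11 log units; within the scatter) from compound 1 to compound 3 and a 1.5-fold lower number (0.16 log units; within the scatter) from compound 2 to compound 4, 1.1-fold (0.05 log units) apart, within the scatter of two such steps

Within this pair of cores, one ending in 4-methylpiperazin-1-yl and the other in piperidin-1-yl, the change therefore carries over with no step size that can be told apart, but each step also stays within the scatter, so neither pair shows that chloro alters the read-out at all. Nor do the two steps show that the place of the chloro is without consequence, since it enters para to a large group in compound 3 and ortho to a large group and meta to a chloro group in compound 4, and two pairs in one cell assay cannot support a rule for the wider series.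

The compounds shown leave open whether the 2,4-dichlorophenyl group gives a comparable reading on the core of compound 3, where the chain ends in 4-methylpiperazin-1-yl. They also leave open whether a different group on the phenyl ring, such as methoxy, trifluoromethyl or nitrile, or a morpholin-4-yl group at the end of the chain, would move the number beyond the scatter.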